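Pyridyl Ether Replaces the Carbamate on the Side Chain

The compounds below may be only part of what the source reports. "The series", "measured", "known", "first", "only" and "open" are said of these compounds alone.

Measured in an assay on frontal cortex for displacement of a labelled ligand from corticotropin-releasing factor receptor 1 (Rattus norvegicus), with a stated time of 2 h; on this read-out higher numbers stand for weaker inhibition and lower numbers for stronger inhibition:
compound 1, `COc1nc(C)c(Nc2nc(Cl)cn([C@H](COC(C)=O)C3CC3)c2=O)cc1C`, gives 5.3 nM
compound 2, `COc1nc(C)c(Nc2nc(Cl)cn([C@H](COC(=O)c3ccccc3)C3CC3)c2=O)cc1C`, gives 1.5 nM
compound 3, `CCNC(=O)OC[C@H](C1CC1)n1cc(Cl)nc(Nc2cc(C)c(OC)nc2C)c1=O`, gives 14 nM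

All three share one core and differ only in the group on the oxygen of the side chain. Compound 3, with its ethylcarbamoyl group, shows the highest number of the three in this assay: a 2.6-fold higher number from compound 1 to compound 3 (0.42 log units; beyond the scatter) and a 9.3-fold higher number from compound 2 to compound 3 (0.97 log units; beyond the scatter).

Compound 4, `COc1nc(C)c(Nc2nc(Cl)cn([C@H](COc3ccc(C(F)(F)F)cn3)C3CC3)c2=O)cc1C`, carries the change (5-(trifluoromethyl)pyridin-2-yl in place of ethylcarbamoyl on an oxygen on a saturated carbon). The step that bears most on it is the one from the aromatic benzoyl group to the carbamate: a 9.3-fold higher number from compound 2 to compound 3 (0.97 log units; beyond the scatter). The smaller step of a 3.5-fold lower number from compound 1 to compound 2 (0.55 log units; beyond the scatter) shows that an aromatic ring in this spot went with a lower number as well. Compound 4 again places an aromatic ring here, though without a carbonyl, so the exact size cannot be taken from any measured pair.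

Compound 4 is therefore expected to show a lower number than compound 3 in this assay, a step of a 4.7-fold lower number from compound 3 to compound 4 (0.67 log units; beyond the scatter). The estimate for compound 4 is 3 nM, with a range from 1 nM to 10 nM.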

Compound 4, half-maximal inhibitory concentration: 1.6 nM
Compound 4: the middle estimate sits 1.9-fold (0.27 log units) above what was measured; the range from low to high includes it.
By their numbers in this assay, from the lowest: compounds 2 and 4 (each within the scatter of the next); then compound 1; then compound 3.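

The side-chain oxygen does not need a carbonyl on it to reach the low numbers in this assay: swapping ethylcarbamoyl for 5-(trifluoromethyl)pyridin-2-yl gives an 8.8-fold lower number from compound 3 to compound 4 (0.94 log units; beyond the scatter), and swapping acetyl for the same ring gives a 3.3-fold lower number from compound 1 to compound 4 (0.52 log units; beyond the scatter). Against the benzoyl group the picture is level, with a 1.1-fold higher number from compound 2 to compound 4 (0.03 log units; within the scatter), which lies within the scatter, so an aromatic ring joined directly to this oxygen does as well as one held on a carbonyl. Across these four compounds, the two groups with an aromatic ring give the lowest numbers, while the two without one, acetyl and ethylcarbamoyl, give higher numbers, and none of the four goes against this pattern.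

No evidence is available on why the numbers shift in this way. From the compounds shown here alone, it also stays open whether the ring itself or its trifluoromethyl group matters more: a plain phenyl or an unsubstituted pyridin-2-yl on this oxygen would separate the two, and a saturated cyclohexyl would test whether the ring has to be aromatic at all.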